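Removing the bromo from compound 3

The source may report more compounds than this note shows. Statements on the series, on what has been measured and on what is new or still open speak of the compounds shown alone.

Measured compounds:
compound 1, `O=C(CSc1nc2ccccc2[nH]1)c1ccc([N+](=O)[O-])cc1`: "not active" (no number reported)
compound 2, `Cc1ccc(C(=O)CSc2nc3ccccc3[nH]2)cc1`: 40%
compound 3, `O=C(CSc1nc2ccccc2[nH]1)c1ccc(Br)cc1`: "not active" (no number reported)

Of the compounds shown here, three that share a core have been tested in a functional assay on HT-29 cells (Homo sapiens) for inhibition, read by flow cytometry, tested at 10 uM; on this read-out higher numbers stand for more inhibition at the one concentration tested (going by the name of the read-out) and lower numbers for less inhibition. In this assay compound 2 gives 40%. In this assay compound 1 gives "not active" (no number reported), with no number reported. In this assay compound 3 likewise gives "not active" (no number reported), again with no number reported. Compound 3 therefore stands without a single number in this assay, and it is one of two compounds in this set for which only such an entry exists; only compound 2 carries a number.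

Compound 4, `O=C(CSc1nc2ccccc2[nH]1)c1ccccc1`, has not yet been measured in this assay. It differs from compound 3 in one place: hydrogen in place of bromo on an aromatic carbon. Among the measured compounds shown here, no step between two measured compounds is available to anchor this change, so its size cannot be read from the data. The set gives a number only for compound 2, while compound 1 and compound 3 carry none, so the direction of the step from compound 3 to compound 4 in this assay is open, and a change beyond the scatter in either direction is possible. Compound 4 is expected to give about 20% in this assay, within 0% to 45%.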

Compound 4, a percentage reported as inhibition, at one concentration (the size of the read-out at that concentration, not a potency): "not active" (no number reported)
The entry for compound 4 holds no number, and the estimate cannot be compared.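

In this assay, among the compounds shown here, compound 3 gives "not active" (no number reported) and compound 4 gives "not active" (no number reported), so no step between these two compounds can be read. No measured evidence bears on this result. The compounds shown leave open whether bromo and hydrogen at this place differ at all in inhibition, and by how much.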